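The source may hold more compounds than are shown below. What is called first, only, known or untested is meant among the compounds shown, and "the series" means these compounds.

Working notes on the series. Among the compounds with values here, in a functional assay on L1210 cells (Mus musculus) for inhibition (on this read-out lower numbers stand for stronger inhibition and higher numbers for weaker inhibition), compound 1 `CCC(C)C(NC(=O)NO)C(=O)NC(c1ccccc1)c1ccccc1` gives 54000 nM, the higher of the two actual numbers so far. Compound 3 `CCC(C)C(NC(=O)n1nnc2ccccc21)C(=O)NC(c1ccccc1)c1ccccc1` gives 17000 nM, and the change at the carbonyl carbon is a 3.2-fold lower number from compound 1 to compound 3 (0.50 log units; beyond the scatter).

Compound 4 `CCC(C)C(NC(=O)NO)C(=O)NCc1ccccc1` carries one change from compound 1: hydrogen in place of phenyl on a saturated chain carbon bound to an amide-type nitrogen and an aromatic carbon. That is, hydrogen in place of phenyl on a saturated chain carbon bound to an amide-type nitrogen and an aromatic carbon.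

Within the data shown here, no measured step touches this place. Among the measured compounds shown here, the only step available, a 3.2-fold lower number from compound 1 to compound 3 (0.50 log units; beyond the scatter), falls elsewhere in the molecule and serves only as a guide to size. For direction there is one weak pointer. Compound 2 `CCC(C)C1NC(=O)N(C2CCCC2)C1=O`, which has no phenyl and differs in other places too, gives > 200000 nM, a limit of the assay and not a number.

A step of modest size or somewhat larger is therefore expected in this assay, towards a higher number, meaning weaker inhibition. The estimated step is a 1.9-fold higher number from compound 1 to compound 4 (0.27 log units; within the scatter). For compound 4 the expected value is 100000 nM, with an estimated range of 35000 nM to 220000 nM. A result reported only as a limit would not be surprising.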

Compound 4, half-maximal inhibitory concentration: 126000 nM
For compound 4 the middle estimate is 1.3-fold (0.10 log units) below the measured one; low and high end bracket the measured number.
By their numbers in this assay, from the lowest: compound 3; then compound 1; then compound 4. At a limit, above all of these: compound 2.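

Working notes on this position. In this assay, the phenyl on the saturated chain carbon bound to an amide-type nitrogen and an aromatic carbon now has a measured effect of its own: replacing it with hydrogen gives a 2.3-fold higher number from compound 1 to compound 4 (0.37 log units; beyond the scatter) and so weakens inhibition modestly. The two single changes made from compound 1 therefore move the read-out in opposite directions, as the change at the carbonyl carbon gives a 3.2-fold lower number from compound 1 to compound 3 (0.50 log units; beyond the scatter) and points to stronger inhibition. Within the data shown here, compound 2 remains only a limit of the assay and not a number, so it gives no size for any step: the limit of > 200000 nM in this assay, at which 1 of the 4 values shown sits.

The compounds shown leave open whether the loss follows from the removal of this phenyl specifically, since a methyl group or a cyclohexyl ring at the same place would be needed to separate the presence of a ring from the presence of any carbon substituent. They also leave open whether the change at the carbonyl carbon gives a step of similar size when hydrogen stands in place of phenyl, because no compound shown carries both changes.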